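The compounds below may be only part of what the source reports. "The series", "measured", "known", "first", "only" and "open" are said of these compounds alone.

Compound 2, drawn as `COCCNC(=O)/C=C/c1cnc(Nc2ccc(C#N)cc2)nc1Oc1c(C)cc(C#N)cc1C`, is known in an ADME assay on TZM cells (Homo sapiens) for cytotoxicity, with a stated time of 1 days (on this read-out higher numbers stand for lower toxicity in this test and lower numbers for higher toxicity in this test), only as a limit of the assay and not as a number, namely > 213 nM. Compound 1, drawn as `C#CCNC(=O)/C=C/c1cnc(Nc2ccc(C#N)cc2)nc1Oc1c(C)cc(C#N)cc1C`, likewise gives in this assay a limit, > 222 nM. Within the data shown here, the one measured step, a step that the two limits leave unreadable from compound 1 to compound 2, therefore cannot be read for size or direction, and the two limits the limit of > 213 nM in this assay, at which 1 of the 2 values shown sits, and the limit of > 222 nM in this assay, at which 1 of the 2 values shown sits, are all the evidence that is available. Compound 3, drawn as `Cc1cc(C#N)cc(C)c1Oc1nc(Nc2ccc(C#N)cc2)ncc1/C=C/C(=O)NCC1CCN(S(C)(=O)=O)CC1`, differs from compound 2 by 1-(methylsulfonyl)piperidin-4-yl in place of methoxymethyl on a saturated chain carbon bound to an amide-type nitrogen; cut one bond further out, the change reads 2-methoxyethyl to (1-(methylsulfonyl)piperidin-4-yl)methyl. Among the measured compounds shown here, no measured step bears on this change with a readable size, so no step beyond the scatter is expected in this assay, and the result for compound 3 is expected most likely to be another limit. His estimate for compound 3 in this assay is 300 nM, within 120 nM to 1500 nM, meaning an expected step that the limit leaves unreadable from compound 2 to compound 3.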

Compound 3, half-maximal cytotoxic concentration: > 171 nM
Compound 3 was reported as a limit (the forecaster's own chance of this, stated with the estimate: 70%); the middle value is on the limit's open side.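

Among these compounds, compound 1, compound 2 and compound 3 are all known only as limits in this assay, so no step among them can be read. The compounds shown leave open whether changing the group on the saturated chain carbon bound to an amide-type nitrogen alters this read-out at all.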